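The source may report more compounds than this note shows. Statements on the series, on what has been measured and on what is new or still open speak of the compounds shown alone.

Compound 1, `C=C1C[C@]23C[C@@]1(O)CC[C@@H]2c1cccc(C)c1[C@@H]3Cn1cc(-c2ccc(Cl)cc2)nn1`, was tested in a functional assay on MCF7 cells (Homo sapiens) for cytotoxicity, read by MTT assay, with a stated time of 4 days; a higher number here means a weaker inhibitor, a lower number a stronger inhibitor. In this assay compound 1 gives > 20000 nM, which is a limit of the assay and not a measured number. Among the measured compounds shown here, compound 2, `Cc1ccc(-c2cn(C[C@H]3c4c(ccc(O)c4C)[C@@H]4CC[C@@]5(C)C[C@]43CC5=O)nn2)cc1`, is the only other compound measured here. In this assay compound 2 also gives > 20000 nM, again a limit rather than a number. For the measured compounds named here, compound 1 therefore stands at the edge of what this assay reports, (the limit of > 20000 nM in this assay, at which 2 of the 2 values shown sit), and no step between two measured compounds is available to show how a single structural change moves the read-out.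

Compound 3, `C=C1C[C@]23C[C@@]1(O)CC[C@@H]2c1cccc(C)c1[C@@H]3Cn1cc(-c2ccc(C(F)(F)F)cc2)nn1`, has not yet been measured. It differs from compound 1 by trifluoromethyl in place of chloro on an aromatic carbon. Going by the values given here, nothing among the measured compounds shows what this exchange does in this assay. Because compound 1 gives only the limit > 20000 nM, the step from compound 1 to compound 3 is expected to be no change beyond the scatter, a step that the limit leaves unreadable from compound 1 to compound 3. Compound 3 is accordingly expected to give 30000 nM, within a range of 10000 nM to 100000 nM, most likely reported once more only as a limit.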

Compound 3, half-maximal inhibitory concentration: > 20000 nM
Compound 3: only a limit was reported; the forecaster's own chance of this, stated with the estimate: 80%; the middle value lies beyond the limit too.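

In this assay compound 3 gives > 20000 nM, which is a limit of the assay and not a number. Compound 1 also stands at a limit, so no step from chloro to trifluoromethyl can be read between compound 1 and compound 3: the limit of > 20000 nM in this assay, at which 3 of the 3 values shown sit.

The compounds shown leave open whether any structural change would yield a measurable value in this assay.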